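Removing a methyl from a hydroxamate-bearing kinase-type scaffold

The source may report more compounds than this note shows. Statements on the series, on what has been measured and on what is new or still open speak of the compounds shown alone.

Measured compounds:
- compound 1, `COc1cc2c(Oc3ccc(NC(=O)c4nn(-c5ccccc5C)cc(C)c4=O)cc3)ccnc2cc1OCCCCCC(=O)NO`: 290 nM
- compound 2, `COc1cc2c(Oc3ccc(NC(=O)c4nn(-c5ccccc5C)ccc4=O)cc3)ccnc2cc1OCCCCCC(=O)NO`: 700 nM
- compound 3, `COc1cc2c(Oc3ccc(NC(=O)c4nn(-c5ccccc5C)cc(C)c4=O)cc3F)ccnc2cc1OCCCC(=O)NO`: 2040 nM

All three were tested in a functional assay on HCT-116 cells (Homo sapiens) for inhibition, read by MTT assay, with a stated time of 72 h; on this read-out lower numbers stand for stronger inhibition and higher numbers for weaker inhibition. Compound 1 gives 290 nM, and compound 2 gives 700 nM. The two differ in one place only, (hydrogen in place of methyl on an aromatic carbon), and that change produced a 2.4-fold higher number from compound 1 to compound 2 (0.38 log units; beyond the scatter). Compound 3 gives 2040 nM, the highest of the three numbers; how its core differs from that of compound 1 is not broken down here.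

Compound 4, `COc1cc2c(Oc3ccc(NC(=O)c4nn(-c5ccccc5)cc(C)c4=O)cc3F)ccnc2cc1OCCCC(=O)NO`, has not yet been measured. It differs from compound 3 by hydrogen in place of methyl on an aromatic carbon. Within the data shown here, this is the same kind of change as the one from compound 1 to compound 2, but not the same: in compound 2 the hydrogen enters on a six-membered aromatic ring with 2 nitrogen, two atoms from the ring nitrogen and meta to a 2-methylphenyl group, whereas in compound 4 it enters on a six-membered aromatic ring of carbon only, ortho to a large group, so that a 2-methylphenyl becomes a phenyl.

Because the earlier step, a 2.4-fold higher number from compound 1 to compound 2 (0.38 log units; beyond the scatter), was a modest loss, and because compound 3 already stands at 2040 nM, a similar, modest rise is expected here. The step from compound 3 to compound 4 is estimated as a 1.6-fold higher number from compound 3 to compound 4 (0.20 log units; within the scatter). For compound 4 in this assay the expected value is 3200 nM, with a likely range from 1300 nM to 8000 nM.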

Compound 4, half-maximal inhibitory concentration: 660 nM
The estimate for compound 4 lay 4.8-fold (0.69 log units) above the measured number; the whole stated range lies above it.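

In this assay, taking the methyl away from the 2-methylphenyl group gave a 3.1-fold lower number from compound 3 to compound 4 (0.49 log units; beyond the scatter), so the number fell here, whereas it rose when a methyl was replaced by hydrogen on the other ring, and the two steps clearly disagree: the same change on two cores in this assay, a 2.4-fold higher number (0.38 log units; beyond the scatter) from compound 1 to compound 2 and a 3.1-fold lower number (0.49 log units; beyond the scatter) from compound 3 to compound 4, 7.5-fold (0.87 log units) apart, beyond the scatter of two such steps For this series, then, replacing a methyl with hydrogen cannot be treated as a change with one fixed effect that carries over from one compound pair to the next, and the earlier step alone would have pointed in the wrong direction. What these two steps do not show is what sets the direction, since the methyl leaves a different ring in each pair and the two pairs also differ elsewhere in their structures, so the place of the change and the surrounding core cannot be told apart.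

The compounds shown leave open how the same change from 2-methylphenyl to phenyl would read on the core of compound 1, a comparison that would help separate the effect of place from that of core. They also leave open whether an ethyl group or a chlorine atom in place of that methyl would give a number nearer to that of compound 3 or of compound 4.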